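Benzofuran-2-yl for Furan-3-yl on Two Shared Cores

This account rests on a few compounds, and the source may have more. Where it says the series, first, only, none or still open, it means among the compounds named here.

Compound 1 `O=c1[nH]cnc2c1c(-c1ccoc1)cn2[C@@H]1O[C@H](CO)[C@@H](O)[C@H]1O` gives 12100 nM in a functional assay on HepG2 cells (Homo sapiens) for antiproliferative activity, read by XTT assay, with a stated time of 72 h; on this read-out lower numbers stand for stronger inhibition and higher numbers for weaker inhibition. Compound 2 `O=c1[nH]cnc2c1c(-c1cc3ccccc3o1)cn2[C@@H]1O[C@H](CO)[C@@H](O)[C@H]1O` reaches only the limit of this assay, > 20000 nM. Compound 3 `Nc1nc(N)c2c(-c3ccoc3)cn([C@@H]3O[C@H](CO)[C@@H](O)[C@H]3O)c2n1` likewise sits at the limit of this assay, > 20000 nM.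

Within the core of compound 1, the change 1-benzofuran-2-yl in place of furan-3-yl on an aromatic carbon gave an at least 1.6-fold higher number from compound 1 to compound 2 (0.21 log units; that floor lies within the scatter). That floor reflects (the limit of > 20000 nM in this assay, at which 2 of the 3 values shown sit), so the true size of the step is not known beyond it.

Compound 3 carries a different core; the difference between the two cores is not broken down here. Compound 4 `Nc1nc(N)c2c(-c3cc4ccccc4o3)cn([C@@H]3O[C@H](CO)[C@@H](O)[C@H]3O)c2n1` is the not yet measured partner of compound 3, and the change 1-benzofuran-2-yl in place of furan-3-yl on an aromatic carbon is the same change as that from compound 1 to compound 2, made at the same place of the ring system.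

Since compound 3 already sits at the limit of this assay, > 20000 nM, and the same change in the first pair gave an at least 1.6-fold higher number from compound 1 to compound 2 (0.21 log units; that floor lies within the scatter), compound 4 is expected to stay at that limit as well. Compound 4 is therefore estimated at 40000 nM, with a range from 15000 nM to 120000 nM. The expected step that the limit leaves unreadable from compound 3 to compound 4 is an estimate that rests on nothing more than the two pairs shown, and a number below the limit would go against it.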

Compound 4, half-maximal inhibitory concentration: > 20000 nM
Compound 4: only a limit was reported (the forecaster's own chance of this, stated with the estimate: 90%); the middle value is on the limit's open side.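

In this assay compound 4 gives > 20000 nM, which is a limit and not a number, and compound 3 stands at that same limit, so no step can be read between compound 3 and compound 4: the limit of > 20000 nM in this assay, at which 3 of the 4 values shown sit.

The compounds shown leave open how large the change from furan-3-yl to 1-benzofuran-2-yl really is on either core, and whether its size differs between the core of compound 1 and the core of compound 3.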